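The source may hold more compounds than are shown below. What is called first, only, known or untested is meant among the compounds shown, and "the series" means these compounds.

Notes on the series. Compound 2 `Cc1ccc(-c2cs/c(=N/NC(=O)CSc3nncn3C)n2-c2ccccc2)cc1` in a functional assay on C6 cells (Rattus norvegicus) for cytotoxicity, read by MTT assay, with a stated time of 24 h, tested at 6 ug/mL (a lower number here means a stronger effect, a higher number a weaker effect of the compound at the concentration tested), gives 74.6%. For the measured compounds named here, the one other measured member, compound 1 `Cc1ccc(-c2cs/c(=N/NC(=O)CSc3nnnn3-c3ccccc3)n2-c2ccccc2)cc1`, gives 66.8% in this assay; the two values sit within the scatter of each other, a number 7.8 percentage points higher from compound 1 to compound 2 (within the scatter), so neither can be set apart from the other on these numbers. Compound 3 `Cc1ccc(-c2cs/c(=N/NC(=O)CSc3nnnn3C)n2-c2ccccc2)cc1` has not yet been measured in this assay. It differs from compound 2 in a single place: 1-methyl-1H-tetrazol-5-yl in place of 4-methyl-4H-1,2,4-triazol-3-yl on a sulfur. Going by the values given here, the one measured step that touches this part of the molecule, a number 7.8 percentage points higher from compound 1 to compound 2 (within the scatter), exchanged the whole group on the sulfur, ring and substituent together, and stayed within the scatter. The change to compound 3 keeps the methyl and alters the ring alone, so no step beyond the scatter is expected for compound 3 in this assay, the expected step being a number 2.6 percentage points lower from compound 2 to compound 3 (within the scatter). The estimate for compound 3 in this assay is 72%, with a range from 58% to 86%.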

Compound 3, a percentage reported as activity, at one concentration (the size of the read-out at that concentration, not a potency): 88%
For compound 3 the middle estimate is 16 percentage points below the measured one, outside the stated range (above it).
By their numbers in this assay, from the lowest: compounds 1 and 2 (each within the scatter of the next); then compound 3.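

In this assay the ring on the sulfur counts on its own: with the methyl kept, 1-methyl-1H-tetrazol-5-yl in place of 4-methyl-4H-1,2,4-triazol-3-yl gives a number 13.4 percentage points higher from compound 2 to compound 3 (beyond the scatter) and so a weaker effect at the concentration tested. The substituent on the aromatic nitrogen also counts, as methyl in place of phenyl on the tetrazole gives a number 21.2 percentage points higher from compound 1 to compound 3 (beyond the scatter) in the same direction, whereas the earlier exchange of ring and substituent together stayed within the scatter. Nothing at hand accounts for either step.

On these data alone, it remains open whether an ethyl or benzyl group on that nitrogen would give a value nearer to that of the methyl or the phenyl compound. Also open, as far as these compounds go, is how a tetrazole without a nitrogen substituent, or a carboxylic acid in place of the ring on the sulfur, would read out.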